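Swapping acetyl for dimethylamino on a weak growth inhibitor

A few compounds are considered here, and "the series" means these few. Any claim that something is new, unique, unknown or untested is made for them only; others in the source may bear on it.

Compound 1 `CC(=O)c1ccc(/C=C(/Sc2ccc(C)cc2)C(=O)c2ccc(Br)cc2)cc1` was tested in a functional assay on DU-145 cells (Homo sapiens) for inhibition, read by trypan blue exclusion, with a stated time of 96 h (a higher number here means a weaker inhibitor of growth, a lower number a stronger inhibitor of growth), and gave 50000 nM. Among the three compounds measured so far, this is the highest number, so compound 1 is the weakest inhibitor of growth in this set. Compound 2 `O=C(/C(=C\c1ccc(Cl)cc1Cl)S(=O)(=O)c1ccc(Br)cc1)c1ccc(Br)cc1` gives 10000 nM in this assay, and compound 3 `COc1ccc(C(=O)/C(=C\c2ccc(OC)c(O)c2)Sc2ccc(F)cc2)cc1` gives 1000 nM; both gaps to compound 1 lie beyond the usual scatter. Neither compound 2 nor compound 3 differs from compound 1 in only one place, so they show where compound 1 stands but do not point to any single change.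

Compound 4 `Cc1ccc(S/C(=C/c2ccc(N(C)C)cc2)C(=O)c2ccc(Br)cc2)cc1` differs from compound 1 in one place: dimethylamino in place of acetyl on an aromatic carbon. The change sits on an aromatic carbon of a six-membered aromatic ring of carbon only. For the measured compounds named here, no measured pair in this set isolates this difference, so the expected direction rests on the structures alone. A moderate improvement is expected, that is, a step downward that goes somewhat beyond the scatter, as the estimated change a 3.3-fold lower number from compound 1 to compound 4 (0.52 log units; beyond the scatter) from compound 1 to compound 4 expresses. Compound 4 is therefore expected to give about 15000 nM in this assay, with a plausible range from 3000 nM to 50000 nM.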

Compound 4, concentration for 50% growth inhibition: > 100000 nM
Compound 4 was reported as a limit; the forecaster's own chance of this, stated with the estimate: 20%; middle value at least 6.6-fold (0.82 log units) away from the limit.
By their numbers in this assay, from the lowest: compound 3; then compound 2; then compound 1. At a limit, above all of these: compound 4.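

In this assay compound 4 gives > 100000 nM, which is a limit of the assay and not a number. The step reads an at least 2.0-fold higher number from compound 1 to compound 4 (0.30 log units; that floor lies within the scatter), so at this place, para to a large group, dimethylamino in place of acetyl brings no gain in growth inhibition, and the true size of the step stays unknown, resting as it does on a limit: the limit of > 100000 nM in this assay, at which 1 of the 4 values shown sits.

For the compounds shown here, compounds 2 and 3 differ from compound 1 in more than one place and could only show where it stands, so this pair gives the first direct reading of what a single change at this position does.

This one pair cannot separate what acetyl contributes from what dimethylamino contributes, and it cannot say whether the same swap would behave alike on a different core. A carboxylic acid or a primary amine at this same place, on the core of compound 1, would show whether any group here can move the number downward from that of compound 1.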